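Aryl ether versus aryl thioether on the diamine core

A few compounds are considered here, and "the series" means these few. Any claim that something is new, unique, unknown or untested is made for them only; others in the source may bear on it.

Compound 1 `Nc1cc(N)c2nc(-c3ccccc3)c(Oc3ccc(Cl)c(Cl)c3)nc2c1` gives 14500 nM in a functional assay on PC-3 cells (Homo sapiens) for inhibition, read by sulforhodamine B assay, with a stated time of 48 h; on this read-out lower numbers stand for stronger inhibition of growth and higher numbers for weaker inhibition of growth.
Compound 2 `COc1ccc(Sc2nc3cc(N)cc(N)c3nc2-c2ccccc2)cc1` gives 5130 nM in this assay.

Of the two numbers, compound 2 holds the lower; compound 1 lies above it by a 2.8-fold lower number from compound 1 to compound 2 (0.45 log units; beyond the scatter), a modest step beyond the scatter. Compound 3 `Nc1cc(N)c2nc(-c3ccccc3)c(Oc3ccc(F)cc3)nc2c1` differs from compound 2 by 4-fluorophenoxy in place of (4-methoxyphenyl)sulfanyl on an aromatic carbon. For the measured compounds named here, the one measured step that bears on this is the same exchange of an aryl ether for an aryl thioether, seen as a 2.8-fold lower number from compound 1 to compound 2 (0.45 log units; beyond the scatter); compound 3 runs that exchange back, though with a different ring substitution, so the earlier step gives only a rough guide. A modest rise in the number is therefore expected for compound 3, about a 1.8-fold higher number from compound 2 to compound 3 (0.24 log units; within the scatter), not a full return to compound 1. The estimate for compound 3 in this assay is 9000 nM, with a range from 3000 nM to 28000 nM.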

Compound 3, concentration for total growth inhibition: 27500 nM
The estimate for compound 3 lay 3.1-fold (0.49 log units) below the measured number, and the stated range covers the measured number.
By their numbers in this assay, from the lowest: compound 2; then compounds 1 and 3 (each within the scatter of the next).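

For the compounds shown here, compound 2 now stands apart from both aryl ethers: in this assay, the exchange of (4-methoxyphenyl)sulfanyl for 4-fluorophenoxy on this aromatic carbon gives a 5.4-fold higher number from compound 2 to compound 3 (0.73 log units; beyond the scatter) and, among the three compounds, the sole thioether has the lowest number, with no compound going against this. On the oxygen, the exchange of 3,4-dichlorophenyl for 4-fluorophenyl gives a 1.9-fold higher number from compound 1 to compound 3 (0.28 log units; within the scatter) and so does not separate the two ethers. No measurement bears on why the sulfanyl compound differs from the ethers.

Each step from compound 2 changes the linking atom and the ring substituent together, so their separate contributions remain unresolved. A 4-fluorophenylsulfanyl group would isolate the linking atom, while a phenylamino group would test a nitrogen link at this position.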